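The source may hold more compounds than are shown below. What is called first, only, known or untested is meant among the compounds shown, and "the series" means these compounds.

Three compounds that share a core have so far been run in an ADME assay on WI-38 cells (Homo sapiens) for cytotoxicity, read by MTT assay, with a stated time of 24 h; on this read-out lower numbers stand for stronger inhibition and higher numbers for weaker inhibition. Compound 1 `N=C(N)c1ccc(-c2ccc(-c3ccc(F)cc3)s2)cc1` gives 197000 nM in this assay. Compound 3 `COc1cc(OC)cc(-c2ccc(-c3ccc(C(=N)N)c(F)c3)s2)c1` gives 123000 nM. Compound 2 `N=C(N)c1ccc(-c2ccc(-c3ccc(Cl)cc3)s2)cc1F` gives 53100 nM, the lowest number of the three: compound 3 stands nearest to it, at a step beyond the usual scatter, and compound 1 stands furthest from it, also beyond the scatter. Among the compounds with values here, compound 2 is thus the strongest inhibitor among the three measured so far.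

The next compound in line is compound 4 `COc1ccc(-c2ccc(-c3ccc(C(=N)N)c(F)c3)s2)cc1`, which has not yet been measured in this assay. It differs from compound 2 in one place: methoxy in place of chloro on an aromatic carbon. Within the data shown here, no measured pair in this set carries that same change, so the direction of the step can only be guessed from the surrounding numbers. Compound 3, which carries methoxy groups, gives a higher number than compound 2, and compound 1, which carries no chloro, gives the highest number of all; on that basis a modest rise is expected from the chloro to the methoxy compound. The step that is expected in this assay a 1.9-fold higher number from compound 2 to compound 4 (0.27 log units; within the scatter) would leave compound 4 weaker than compound 2 but stronger than compound 1. Compound 4 is therefore estimated at 100000 nM in this assay, within a range from 40000 nM to 250000 nM.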

Compound 4, half-maximal inhibitory concentration: 104000 nM
Beside the measured number, compound 4's estimate is 1.0-fold (0.02 log units) below it, within the range that was stated.
By their numbers in this assay, from the lowest: compounds 2, 4, 3 and 1 (each within the scatter of the next, the first and the last beyond it).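

In this assay, within the data shown here, the exchange of chloro for methoxy on an aromatic carbon, para to a large group, gives a 2.0-fold higher number from compound 2 to compound 4 (0.29 log units; within the scatter) and so provides the first pair in this set that differs in one place. At this position, on a six-membered aromatic ring of carbon only, the read-out therefore does not separate chloro from methoxy, even though the change adds a heavy atom and a hydrogen-bond acceptor. Nothing available explains why the two groups read alike in this cytotoxicity measurement.

The compounds shown leave open whether any group at this position can move the number beyond the scatter, since an amine, a carboxylic acid or a longer chain such as butoxy does not appear among them. They also leave open whether the same exchange of chloro for methoxy would give a similarly small step at another place on the shared core, as this single pair speaks only for the position it covers.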